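A few compounds are considered here, and "the series" means these few. Any claim that something is new, unique, unknown or untested is made for them only; others in the source may bear on it.

In a functional assay, with a stated time of 10 min (a higher number here means a weaker inhibitor, a lower number a stronger inhibitor), compound 1 `CCCCCCCCOc1cc(OC)c(Br)cc1C(C)=O` gives 38100000 nM and compound 2 `CCCCCCCCCCCCOc1cc(OC)c(Br)cc1C(C)=O` gives 23100000 nM, so the two stand level. That single measured step, a 1.6-fold lower number from compound 1 to compound 2 (0.22 log units; within the scatter), concerns the chain only and stays within the scatter. Compound 3 `CCCCCCCCOc1cc(OC)ccc1C(C)=O` differs from compound 1 by hydrogen in place of bromo on an aromatic carbon. Among the measured compounds shown here, no measured step covers this change, so nothing supports expecting a shift beyond the scatter, and the range stays wide. The expected step is a 1.1-fold lower number from compound 1 to compound 3 (0.04 log units; within the scatter). Compound 3 is estimated at 35000000 nM, with an expected range from 11000000 nM to 110000000 nM.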

Compound 3, half-maximal inhibitory concentration: 69400000 nM
The estimate for compound 3 lay 2.0-fold (0.30 log units) below the measured number; the measured number falls inside the stated range.
By their numbers in this assay, from the lowest: compounds 2, 1 and 3 (each within the scatter of the next, the first and the last beyond it).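

In this assay, among the compounds shown here, hydrogen in place of bromo on the aromatic carbon ortho to a methoxy group and meta to an acetyl group gives a 1.8-fold higher number from compound 1 to compound 3 (0.26 log units; within the scatter), the first reading at this position. Compound 3 therefore stands level with compound 1, and the bromo is not shown to be needed for the activity of this core. Nothing available gives a reason for this result.

From the compounds shown here alone, whether a different group here, such as chloro, an amine or a carboxylic acid, would move the number beyond the scatter remains open. So does the effect of a longer chain without the bromo.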